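Dichlorophenyl in Place of Methoxyphenyl on a Shared Core

The source may hold more compounds than are shown below. What is called first, only, known or untested is meant among the compounds shown, and "the series" means these compounds.

Compound 2 `COc1ccc(/C=C2/N=C(c3ccccc3)N(c3ccc4oc(-c5ccccc5)cc(=O)c4c3)C2=O)cc1` gives 21.7 ug/mL in a functional assay on MDA-MB-435 cells (Homo sapiens) for inhibition, read by sulforhodamine B assay; a higher number here means a weaker inhibitor, a lower number a stronger inhibitor. Going by the values given here, it stands within the scatter of the only other compound measured, compound 1 `O=C1/C(=C\c2ccccc2)N=C(c2ccccc2)N1c1ccc2oc(-c3ccccc3)cc(=O)c2c1`, which in this assay gives 26.4 ug/mL; the single measured step, a 1.2-fold lower number from compound 1 to compound 2 (0.09 log units; within the scatter), is therefore no more than noise. Compound 3 `O=C1/C(=C\c2ccc(Cl)c(Cl)c2)N=C(c2ccccc2)N1c1ccc2oc(-c3ccccc3)cc(=O)c2c1` has not yet been measured. It differs from compound 2 by 3,4-dichlorophenyl in place of 4-methoxyphenyl on a double-bonded chain carbon bound to a double-bonded ring carbon. Among the compounds with values here, no measured step has tried a change of this kind, and the one step in hand, a 1.2-fold lower number from compound 1 to compound 2 (0.09 log units; within the scatter), stayed within the scatter when the group on that double-bonded chain carbon was altered, so nothing in the data points to a step beyond the scatter in this assay in either direction. Compound 3 is therefore expected to give about 18 ug/mL, with a range from 8 ug/mL to 40 ug/mL. The expected step is a 1.2-fold lower number from compound 2 to compound 3 (0.08 log units; within the scatter), within the scatter.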

Compound 3, half-maximal inhibitory concentration: 20.2 ug/mL
For compound 3 the middle estimate is 1.1-fold (0.05 log units) below the measured one; the range from low to high includes it.
By their numbers in this assay, from the lowest: compounds 3, 2 and 1 (each within the scatter of the next).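

At the double-bonded chain carbon bound to a double-bonded ring carbon, putting 3,4-dichlorophenyl in place of 4-methoxyphenyl gives a 1.1-fold lower number from compound 2 to compound 3 (0.03 log units; within the scatter) in this assay, and putting it in place of phenyl gives a 1.3-fold lower number from compound 1 to compound 3 (0.12 log units; within the scatter). The earlier compounds had shown only that a methoxy group on this phenyl ring left the number within the scatter; compounds 1, 2 and 3 now show that a ring bearing two chlorines does so too, and none of the three goes against this. No measurement shown offers an explanation for this flat result.

Going by these compounds, whether an amine or a carboxylic acid at this place would give a step beyond the scatter remains open. So does whether this flat result would hold if the other groups on the shared core were changed.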